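Replacing 2-(benzyloxy)ethyl with cyclopentyl: working notes

A few compounds are considered here, and "the series" means these few. Any claim that something is new, unique, unknown or untested is made for them only; others in the source may bear on it.

In an ADME assay on L6 cells (Rattus norvegicus) for cytotoxicity (on this read-out higher numbers stand for weaker inhibition and lower numbers for stronger inhibition), compound 2 (`OC[C@H]1O[C@@H](n2cnc3c(NCc4cccc(I)c4)nc(NCCOCc4ccccc4)nc32)[C@H](O)[C@@H]1O`) stands at "not determined" (no result reported), so it offers no number from which to measure a step. The only figure in the series comes from compound 1 (`OC[C@H]1O[C@@H](n2cnc3c(NC4CCCC4)nc(NC4CCCC4)nc32)[C@H](O)[C@@H]1O`), which gives 97300 nM. Compound 3 (`OC[C@H]1O[C@@H](n2cnc3c(NCc4cccc(I)c4)nc(NC4CCCC4)nc32)[C@H](O)[C@@H]1O`) is reached from compound 2 by this change: cyclopentyl in place of 2-(benzyloxy)ethyl on a nitrogen on an aromatic ring. Cyclopentyl thus takes the place of 2-(benzyloxy)ethyl on a nitrogen on an aromatic ring. Compound 1 also carries cyclopentyl on such a nitrogen, but it differs elsewhere, so it is only a loose anchor. No step size can be derived from compound 2, and in this assay compound 3 is expected to lie near compound 1, with somewhat stronger inhibition at most. For compound 3 the estimated value is 45000 nM, with an expected range of 12000 nM to 130000 nM.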

Compound 3, half-maximal inhibitory concentration: 51700 nM
Compound 3: the middle estimate sits 1.1-fold (0.06 log units) below what was measured; the range from low to high includes it.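

In this assay, going by these compounds alone, the step of a 1.9-fold lower number from compound 1 to compound 3 (0.27 log units; within the scatter) is the first change that can be read, and it lies within the scatter. On this read-out, 3-iodobenzyl in place of cyclopentyl on a nitrogen on an aromatic ring therefore gives no distinguishable change in this single pair, while the step from compound 2 to compound 3 cannot be read, as compound 2 has no number. No supporting data bear on this result.

From the compounds shown here alone, the size of any effect of cyclopentyl in place of 2-(benzyloxy)ethyl remains open. Going by these compounds, it is also open whether a carboxylic acid, an amine or a longer alkyl chain in place of cyclopentyl on this nitrogen would give a number outside the scatter.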